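The source may hold more compounds than are shown below. What is called first, only, known or untested is meant among the compounds shown, and "the series" means these compounds.

Measured compounds in a functional assay on HCT-116 cells (Homo sapiens) for antiproliferative activity, read by CCK-8 assay, with a stated time of 72 h, tested at 2 uM; a higher number here means a stronger effect of the compound at the concentration tested, a lower number a weaker effect:
- compound 1, `Nc1ccccc1NC(=O)/C=C/c1ccc(COCNc2nc(Nc3cccc(Cl)c3)c3ncn(C4CCCC4)c3n2)cc1`: 9.04%
- compound 2, `Nc1ccccc1NC(=O)c1ccc(COCNc2nc(Nc3ccccc3)c3ncn(C4CCCC4)c3n2)cc1`: 75.2%
- compound 3, `CCCCn1cnc2c(Nc3ccccc3)nc(NCOCc3ccc(C(=O)Nc4ccccc4N)cc3)nc21`: 72.9%

Compound 2 gives the highest of the three numbers in this assay. Compound 3, which carries butyl in place of cyclopentyl on an aromatic nitrogen, lies nearest: the step of a number 2.3 percentage points lower from compound 2 to compound 3 (within the scatter) stays within the scatter. Compound 1 lies furthest; its value is well below that of compound 2, beyond the scatter, but compound 1 differs from compound 2 in more than one place (the chloro on the anilino ring and the linker to the amide), so no single step can be read from that pair.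

Compound 4, `Nc1ccccc1NC(=O)c1ccc(COCNc2nc(Nc3cccc(Cl)c3)c3ncn(C4CCCC4)c3n2)cc1`, is the unmeasured one. It differs from compound 2 by chloro in place of hydrogen on an aromatic carbon. Among the compounds with values here, none of the measured steps carries this same change on an otherwise identical scaffold; the only measured step, from compound 2 to compound 3, concerns a different position and was within the scatter. Compound 1 carries both the chloro and the altered linker and gives a low value. Within the data shown here, from these three compounds alone, no step for the chloro by itself can be read. The expectation is therefore uncertain, with a downward lean.

For compound 4 the estimate in this assay is 55%, between 15% and 85%, an expected step of a number 20.2 percentage points lower from compound 2 to compound 4 (beyond the scatter).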

Compound 4, a percentage reported as inhibition, at one concentration (the size of the read-out at that concentration, not a potency): 29.2%
Beside the measured number, compound 4's estimate is 25.8 percentage points above it, within the range that was stated.
By their numbers in this assay, from the lowest: compound 1; then compound 4; then compounds 3 and 2 (each within the scatter of the next).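

In this assay, within the data shown here, phenyl to 3-chlorophenyl on the anilino nitrogen gives a number 46 percentage points lower from compound 2 to compound 4 (beyond the scatter) and is the first single change here with a step beyond the scatter, since the only earlier step, at the aromatic nitrogen, stayed within it. With chloro present in both compounds, (2-aminophenyl)carbamoyl in place of 2-((2-aminophenyl)carbamoyl)ethenyl gives a number 20.2 percentage points higher from compound 1 to compound 4 (beyond the scatter) and so shows that the low number of compound 1 cannot be put on the chloro alone, as the change in the linker also moves the read-out on this scaffold. Nothing at hand explains the size of either step.

Still open, going by these compounds, is whether the loss belongs to chloro itself or to any group at this place on the ring; fluoro, methyl or methoxy there would separate those readings, as would chloro on another carbon of the same ring. Also open, on these data alone, is whether the ethenyl linker lowers the read-out without chloro, and whether butyl and cyclopentyl remain interchangeable on the 3-chlorophenyl scaffold.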